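The compounds below may be only part of what the source reports. "The series", "measured", "known", "first", "only" and "open" are said of these compounds alone.

Measured so far:
Compound 1 `CC1(C)[C@H]2CC[C@]1(C)N(Cc1cn(-c3cccc(C#N)c3)nn1)C(=O)C2`: 230 nM
Compound 2 `CC1(C)[C@H]2CC[C@]1(C)N(Cc1cn(-c3ccccc3F)nn1)C(=O)C2`: 300 nM

In a functional assay on OVCAR-3 cells (Homo sapiens) for inhibition, read by MTT assay, with a stated time of 24 h (a lower number here means a stronger inhibitor, a higher number a weaker inhibitor), compound 1 gives 230 nM. Among the measured compounds shown here, of the two measured numbers this is the lower one, but its only neighbour is compound 2, and a 1.3-fold higher number from compound 1 to compound 2 (0.12 log units; within the scatter) is a gap that lies within the scatter, so the two compounds cannot be told apart on these numbers. Both share the same core and differ only in the aromatic group attached to a ring nitrogen.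

Compound 3 `Cc1ccc(-n2cc(CN3C(=O)C[C@@H]4CC[C@@]3(C)C4(C)C)nn2)cc1` has not yet been measured. It differs from compound 1 in the same place: 4-methylphenyl in place of 3-cyanophenyl on an aromatic nitrogen. For the measured compounds named here, the only step that bears on this change is the one from compound 1 to compound 2, where a different aromatic group was swapped onto that nitrogen and the result, a 1.3-fold higher number from compound 1 to compound 2 (0.12 log units; within the scatter), stayed within the scatter. Going by the values given here, no further step is available.

On that basis a step in this assay of no more than the scatter is expected, in no particular direction. Compound 3 is therefore estimated at about 250 nM, with a range from 120 nM to 520 nM. The expected step of a 1.1-fold higher number from compound 1 to compound 3 (0.04 log units; within the scatter) would thus remain within the scatter.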

Compound 3, half-maximal inhibitory concentration: 40 nM
For compound 3 the middle estimate is 6.3-fold (0.80 log units) above the measured one; measured number below the stated range.
By their numbers in this assay, from the lowest: compound 3; then compounds 1 and 2 (each within the scatter of the next).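

Among the compounds shown here, until this result, changing the aromatic group on this nitrogen had moved the number only within the scatter, so the position could have looked indifferent to what sits there. In this assay the 4-methylphenyl group changes that picture: in place of 3-cyanophenyl it gives a 5.8-fold lower number from compound 1 to compound 3 (0.76 log units; beyond the scatter) and in place of 2-fluorophenyl it gives a 7.5-fold lower number from compound 2 to compound 3 (0.88 log units; beyond the scatter) on the same shared core. This position therefore does respond to the choice of group, and compound 3 stands clearly lowest of the three, while compounds 1 and 2 remain within the scatter of each other.

Nothing measured alongside these compounds accounts for the difference. Each step swaps a whole substituted phenyl group, so these compounds leave open whether the methyl group itself or its place on the phenyl ring matters, a question that 3-methylphenyl, unsubstituted phenyl, 4-ethylphenyl or 4-methoxyphenyl in the same position could help to separate.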